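Chalcone series: amino-to-difluoro swap on the carbonyl-side ring

A few compounds are considered here, and "the series" means these few. Any claim that something is new, unique, unknown or untested is made for them only; others in the source may bear on it.

Measured so far:
compound 1, `COc1ccc(-c2cc(/C=C/C(=O)c3ccc(N)cc3)[nH]n2)cc1`: 92100 nM
compound 2, `COc1cc(-c2cc(/C=C/C(=O)c3ccc(N)cc3)[nH]n2)cc(OC)c1OC`: 7180 nM

In a functional assay on NCI-H226 cells (Homo sapiens) for inhibition, read by sulforhodamine B assay, with a stated time of 48 h (on this read-out higher numbers stand for lower toxicity in this test and lower numbers for higher toxicity in this test), compound 1 gives 92100 nM, and compound 2 gives 7180 nM. Among the compounds with values here, compound 2 therefore holds the lower of the two numbers, with compound 1 standing at a gap that lies beyond the scatter; no single-point step between the two is tabulated, so only the two values themselves are known.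

Compound 3, `COc1cc(-c2cc(/C=C/C(=O)c3ccc(F)c(F)c3)[nH]n2)cc(OC)c1OC`, is not yet measured in this assay. It differs from compound 2 by 3,4-difluorophenyl in place of 4-aminophenyl on a carbonyl carbon. Within the data shown here, no measured pair tracks this exchange, so the expectation rests on compound 2 alone. The step from compound 2 to compound 3 is expected to be small, if anything upward, and not clearly beyond the scatter: a 1.3-fold higher number from compound 2 to compound 3 (0.10 log units; within the scatter). Compound 3 is thus estimated at 9000 nM, within a range of 2500 nM to 35000 nM.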

Compound 3, concentration lethal to 50% of the cells: 66000 nM
For compound 3 the middle estimate is 7.3-fold (0.87 log units) below the measured one; the measured number lies above the stated range.
By their numbers in this assay, from the lowest: compound 2; then compounds 3 and 1 (each within the scatter of the next).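

In this assay the exchange of 4-aminophenyl for 3,4-difluorophenyl on a carbonyl carbon gives a 9.2-fold higher number from compound 2 to compound 3 (0.96 log units; beyond the scatter) and lies beyond the scatter. Within the data shown here, the group at this position therefore moves the read-out, which the earlier compounds, both carrying 4-aminophenyl, could not show. Nothing measured on these compounds explains the step.

Going by these compounds, whether 4-fluorophenyl or 4-(dimethylamino)phenyl at this position would stay nearer compound 2 or compound 3 remains open. So does whether the same exchange on the core of compound 1 would give a step of similar size.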